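This account rests on a few compounds, and the source may have more. Where it says the series, first, only, none or still open, it means among the compounds named here.

Notes on the series. Compound 1 `Cc1nccn1-c1csc(Nc2cccc(Br)c2)n1`, compound 2 `COc1ccc(Nc2nc(-n3cnc4ccccc43)cs2)cc1` and compound 3 `Cc1nc2ccccc2n1-c1csc(Nc2ccc(Br)cc2)n1` share a core and differ only in the groups carried on it. In a functional assay on RKO cells (Homo sapiens) for cytotoxicity, read by resazurin assay, with a stated time of 72 h (on this read-out higher numbers stand for weaker inhibition and lower numbers for stronger inhibition), compound 1 returns no number, only a limit, > 100000 nM. In this assay compound 2 also returns only a limit, > 100000 nM. In this assay compound 3 gives a measured number, 60000 nM. Compound 2 therefore stands at the limit of > 100000 nM in this assay, at which 2 of the 3 values shown sit; its value is a limit, not a number, and cannot be ranked against the others. Among the compounds with values here, no pair of measured compounds differs in a single place, so no measured step is available to read from. Compound 4 `c1ccc(Nc2nc(-n3cnc4ccccc43)cs2)cc1`, not yet measured, differs from compound 2 by hydrogen in place of methoxy on an aromatic carbon. For this step nothing beyond the usual scatter of this assay is expected, in no particular direction; every value in hand is weak. Compound 4 is expected to give about 100000 nM in this assay, within 40000 nM to 300000 nM. The expected step from compound 2 to compound 4 is a number no higher from compound 2 to compound 4 (the limit leaves the size open), most likely ending in a limit once more.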

Compound 4, half-maximal inhibitory concentration: > 100000 nM
Compound 4: a limit, no number (the forecaster's own chance of this, stated with the estimate: 70%); the middle value sits exactly at the limit.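

Compound 2 and compound 4 both return only limits in this assay, and the step between them cannot be read. The compounds shown leave open whether methoxy and hydrogen on this aromatic carbon differ at all in this read-out.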